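Swapping a nitro ester for a chloro ester

The compounds below may be only part of what the source reports. "The series", "measured", "known", "first", "only" and "open" are said of these compounds alone.

Compound 1, `COc1cc(C2Oc3cc([C@H]4Oc5cc(O)cc(O)c5C(=O)[C@@H]4O)ccc3OC2COC(=O)c2ccccc2)ccc1O`, gives 105000 nM in a functional assay, read by spectrophotometry, with a stated time of 30 min; a lower number here means that less compound is needed, a higher number that more compound is needed for the effect.
Compound 2, `COc1cc(C2Oc3cc([C@H]4Oc5cc(O)cc(O)c5C(=O)[C@@H]4O)ccc3OC2COC(=O)c2ccc([N+](=O)[O-])cc2)ccc1O`, gives > 300000 nM in this assay.

Compound 2 thus stands only at a limit of this assay, (the limit of > 300000 nM in this assay, at which 1 of the 2 values shown sits), with no number of its own. Going by the values given here, the one measured step, an at least 2.8-fold higher number from compound 1 to compound 2 (0.45 log units; beyond the scatter), shows that adding the nitro group made more compound necessary. Compound 3, `COc1cc(C2Oc3cc([C@H]4Oc5cc(O)cc(O)c5C(=O)[C@@H]4O)ccc3OC2COC(=O)c2cccc(Cl)c2)ccc1O`, takes the nitro group away again: 3-chlorophenyl in place of 4-nitrophenyl on a carbonyl carbon. Since the limit hides how far compound 2 lies beyond compound 1, the step back is expected to be an at least 2.0-fold lower number from compound 2 to compound 3 (0.30 log units; that floor lies within the scatter), downward, toward the number of compound 1. Compound 3 is estimated at 150000 nM, between 60000 nM and 400000 nM.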

Compound 3, half-maximal effective concentration: 106000 nM
For compound 3 the middle estimate is 1.4-fold (0.15 log units) above the measured one; low and high end bracket the measured number.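

The aromatic ring on this carbonyl carbon can carry a chlorine without leaving the measurable range of this assay, with a 1.0-fold higher number from compound 1 to compound 3 (0.00 log units; within the scatter). Replacing 4-nitrophenyl with 3-chlorophenyl gives an at least 2.8-fold lower number from compound 2 to compound 3 (0.45 log units; beyond the scatter), so the loss seen with the nitro ester does not extend to this chloro ester. That step has no exact size, as compound 2 has only a limit: the limit of > 300000 nM in this assay, at which 1 of the 3 values shown sits.

Compound 3 changes both the group and its place on the ring, and the compounds shown do not separate these two changes. As far as these compounds go, how an amine or a carboxylic acid on this ring would read also remains open.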